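This account rests on a few compounds, and the source may have more. Where it says the series, first, only, none or still open, it means among the compounds named here.

Within the data shown here, in a functional assay on HEK293 cells for agonist activity at 5-hydroxytryptamine receptor 4 (Homo sapiens), read by cAMP accumulation (on this read-out lower numbers stand for an effect already at smaller amounts and higher numbers for an effect only at larger amounts of compound), compound 3 `COc1cc(N)c(Cl)cc1C(=O)NC1CCN(CCCCCCCCO)CC1` gives 15.9 nM, the lowest of the three numbers measured so far. Compound 2 `CCN1CCC(NC(=O)c2cc(Cl)c(N)cc2OC)CC1` gives 79.4 nM, and compound 1 `COc1cc(N)c(Cl)cc1C(=O)NC1CCNCC1` gives 398 nM. The measured steps all run the same way: a 5.0-fold lower number from compound 1 to compound 2 (0.70 log units; beyond the scatter), a 25-fold lower number from compound 1 to compound 3 (1.40 log units; beyond the scatter), and a 5.0-fold lower number from compound 2 to compound 3 (0.70 log units; beyond the scatter). Compound 4 `COc1cc(N)c(Cl)cc1C(=O)NC1CCN(CCN2CCCCC2)CC1` differs from compound 3 by piperidin-1-yl in place of 6-hydroxyhexyl on a saturated chain carbon, two bonds along the chain from an amine nitrogen in a ring. Among the measured compounds shown here, no measured step matches this exchange directly. The step that bears most closely on it, from compound 2 to compound 3, shows that adding the 6-hydroxyhexyl at this carbon brought a modest gain, so taking it away and placing piperidin-1-yl there could hand part of that back, while a substituent on the amine nitrogen in the ring is kept, which both earlier steps reward. In this assay the expected step is therefore small, a 1.6-fold higher number from compound 3 to compound 4 (0.20 log units; within the scatter), within or not far beyond the scatter. Compound 4 is estimated at 25 nM in this assay, with a range from 6 nM to 100 nM.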

Compound 4, half-maximal effective concentration: 100 nM
Compound 4: middle estimate off by 4.0-fold (0.60 log units), on the low side; the measured number falls inside the stated range.
By their numbers in this assay, from the lowest: compound 3; then compounds 2 and 4 (each within the scatter of the next); then compound 1.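

In this assay, the ring-bearing 2-(piperidin-1-yl)ethyl on the amine nitrogen in a ring still improves on hydrogen there (a 4.0-fold lower number from compound 1 to compound 4 (0.60 log units; beyond the scatter)), so open chains are not the only substituents rewarded at this nitrogen. At the saturated chain carbon, two bonds along the chain from an amine nitrogen in a ring, piperidin-1-yl in place of hydrogen gives only a step within the scatter (a 1.3-fold higher number from compound 2 to compound 4 (0.10 log units; within the scatter)), whereas piperidin-1-yl in place of 6-hydroxyhexyl loses ground (a 6.3-fold higher number from compound 3 to compound 4 (0.80 log units; beyond the scatter)). At this carbon, then, the gain seen with compound 3 does not come with just any group: of the two shown, only 6-hydroxyhexyl gives it.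

Nothing on hand gives a reason for the gap between these two groups. The compounds shown leave open whether that gain rests on the terminal hydroxyl or on the open chain itself, a question that a plain octyl on the same nitrogen would address.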